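From 4-chlorophenyl to 2-bromophenyl on the shared core

The compounds below may be only part of what the source reports. "The series", "measured", "known", "first", "only" and "open" are said of these compounds alone.

Measured in a functional assay on HeLa cells (Homo sapiens) for antiproliferative activity, read by sulforhodamine B assay, with a stated time of 72 h (a higher number here means a weaker inhibitor, a lower number a stronger inhibitor), as half-maximal inhibitory concentration:
- Compound 1 `Fc1ccccc1NC(=S)N/N=C/c1ccc2ccccc2n1` gives > 100000 nM as a limit
- Compound 2 `N#Cc1ccc(NC(=S)N/N=C/c2ccc3ccccc3n2)cc1` gives 20000 nM as a number
- Compound 3 `S=C(N/N=C/c1ccc2ccccc2n1)Nc1ccc(Cl)cc1` gives > 100000 nM as a limit

Compound 3 stands only at a limit (> 100000 nM) and has no number of its own. It rests at the limit of > 100000 nM in this assay, at which 2 of the 3 values shown sit, and so offers no exact starting point. Compound 4 `S=C(N/N=C/c1ccc2ccccc2n1)Nc1ccccc1Br` has not been measured and differs from compound 3 by one change, 2-bromophenyl in place of 4-chlorophenyl on an amide-type nitrogen.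

Two steps can be read, an at least 5.0-fold lower number from compound 1 to compound 2 (0.69 log units; beyond the scatter) and an at least 5.0-fold higher number from compound 2 to compound 3 (0.69 log units; beyond the scatter), both beyond the scatter and both involving the 4-cyanophenyl group, which compound 4 lacks. The limits leave a step that the two limits leave unreadable from compound 1 to compound 3 unreadable. Compound 1, with its 2-fluorophenyl, also gives only a limit (> 100000 nM).

In this assay the expected change is an at least 1.2-fold lower number from compound 3 to compound 4 (0.09 log units; that floor lies within the scatter) and is not expected to be clearly readable. For compound 4 the estimate is 80000 nM, with an expected range of 20000 nM to 150000 nM, and a report of only a limit is quite likely.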

Compound 4, half-maximal inhibitory concentration: > 100000 nM
Compound 4 was reported as a limit; the forecaster's own chance of this, stated with the estimate: 60%; middle value at least 1.2-fold (0.09 log units) away from the limit.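

In this assay, within the data shown here, the change to 2-bromophenyl on the amide-type nitrogen comes with an at least 5.0-fold higher number from compound 2 to compound 4 (0.69 log units; beyond the scatter), so 4-cyanophenyl remains the only group at this place that gives a number, while the others share one limit: the limit of > 100000 nM in this assay, at which 3 of the 4 values shown sit. The steps from compound 3 and from compound 1 to compound 4 have limits at both ends and cannot be read. The halogen-bearing phenyl groups shown, 2-fluorophenyl, 4-chlorophenyl and 2-bromophenyl, therefore all rest at that limit, and only compound 2, with its nitrile, goes against this.

The compounds shown leave open how far each of these three lies past the limit, so no order among them can be given. They also leave open whether an amine or a carboxylic acid on the phenyl group would give a number, as 4-cyanophenyl does.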